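A few compounds are considered here, and "the series" means these few. Any claim that something is new, unique, unknown or untested is made for them only; others in the source may bear on it.

Measured compounds:

compound 1 `CCCn1c(=O)c2nc(-c3cnn(Cc4cccc(C)c4)c3)[nH]c2n(CCC)c1=O` gives 48 nM
compound 2 `CCCn1c(=O)c2nc(-c3cnn(Cc4cc(Cl)ccc4Cl)c3)[nH]c2n(CCC)c1=O` gives 190 nM
compound 3 `CCCn1c(=O)c2nc(-c3cnn(Cc4ccccc4C(F)(F)F)c3)[nH]c2n(CCC)c1=O` gives 44 nM

All three share one core and differ only in the ring attached through a saturated chain carbon bound to an aromatic nitrogen; the values above come from an assay on CHO cells for displacement of a labelled ligand from adenosine receptor A1 (Homo sapiens); a higher number here means a weaker inhibitor, a lower number a stronger inhibitor. Compound 3 has the lowest number of the three, but its nearest neighbour, compound 1, lies within the scatter, as a 1.1-fold lower number from compound 1 to compound 3 (0.04 log units; within the scatter) shows; only compound 2 stands clearly apart, as a 4.3-fold lower number from compound 2 to compound 3 (0.64 log units; beyond the scatter) shows.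

Compound 4 `CCCn1c(=O)c2nc(-c3cnn(Cc4cccc(Cl)c4)c3)[nH]c2n(CCC)c1=O` is not yet measured. The change from compound 3 is 3-chlorophenyl in place of 2-(trifluoromethyl)phenyl on a saturated chain carbon bound to an aromatic nitrogen. Among the compounds with values here, two measured steps bear on this: a 1.1-fold lower number from compound 1 to compound 3 (0.04 log units; within the scatter), which was within the scatter, and a 4.0-fold higher number from compound 1 to compound 2 (0.60 log units; beyond the scatter), which was a modest rise. The 3-chlorophenyl entering resembles the 3-methylphenyl of compound 1 more than the 2,5-dichlorophenyl of compound 2, so little change beyond the scatter is expected in this assay. The expected step is a 1.3-fold higher number from compound 3 to compound 4 (0.10 log units; within the scatter). For compound 4 the estimate is 55 nM, within a range from 25 nM to 130 nM.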

Compound 4, inhibition constant: 31 nM
Beside the measured number, compound 4's estimate is 1.8-fold (0.25 log units) above it, and the stated range covers the measured number.
By their numbers in this assay, from the lowest: compounds 4, 3 and 1 (each within the scatter of the next); then compound 2.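

In this assay, chloro in place of methyl on an aromatic carbon gives a 1.5-fold lower number from compound 1 to compound 4 (0.19 log units; within the scatter), and 3-chlorophenyl in place of 2-(trifluoromethyl)phenyl gives a 1.4-fold lower number from compound 3 to compound 4 (0.15 log units; within the scatter), so this place on the molecule accepts all three of these singly substituted phenyl groups without a change beyond the scatter. The new compound also isolates the effect of the second chloro: hydrogen in place of one chloro of the 2,5-dichlorophenyl group gives a 6.1-fold lower number from compound 2 to compound 4 (0.79 log units; beyond the scatter), so a single chloro does not bring the weaker binding seen with two. Nothing available explains why the second chloro matters.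

The groups shown on the phenyl ring are only chloro, methyl and trifluoromethyl. On these data alone, how an amine, a carboxylic acid or a methoxy group would fare there remains open, as does a longer chain between the phenyl ring and the aromatic nitrogen.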